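Butyl amide versus aryl amides: the next chain variant

The source may hold more compounds than are shown below. What is called first, only, known or untested is meant among the compounds shown, and "the series" means these compounds.

Values in a functional assay on MDA-MB-231 cells (Homo sapiens) for antiproliferative activity, read by MTT assay, with a stated time of 24 h; on this read-out higher numbers stand for weaker inhibition and lower numbers for stronger inhibition:
- compound 1 `CCCCNC(=O)COc1ccc(C(=O)c2c(CCCC)oc3ccccc23)cc1`: 34500 nM
- compound 2 `CCCCc1oc2ccccc2c1C(=O)c1ccc(OCC(=O)Nc2ccccc2)cc1`: > 50000 nM (a limit)
- compound 3 `CCCCc1oc2ccccc2c1C(=O)c1ccc(OCC(=O)N[C@@H](C)c2ccccc2)cc1`: > 50000 nM (a limit)

Compound 3 has no number, only a limit: it sits at the limit of > 50000 nM in this assay, at which 2 of the 3 values shown sit. Compound 4 `CCCCNC(=O)CCCOc1ccc(C(=O)c2c(CCCC)oc3ccccc23)cc1` differs from it as follows: 2-(butylcarbamoyl)ethyl in place of (1-phenylethyl)carbamoyl on a saturated chain carbon bound to an oxygen on an aromatic ring. Compound 4 carries butyl on the amide-type nitrogen, as compound 1 does. For the measured compounds named here, the steps that bear on this are an at least 1.4-fold higher number from compound 1 to compound 2 (0.16 log units; that floor lies within the scatter) and an at least 1.4-fold higher number from compound 1 to compound 3 (0.16 log units; that floor lies within the scatter). The step that the two limits leave unreadable from compound 2 to compound 3 adds nothing. Going by the values given here, no measured step covers the chain itself. Compound 1 at 34500 nM therefore anchors the expectation of a modest move to a lower number in this assay. The expected step is an at least 1.6-fold lower number from compound 3 to compound 4 (0.22 log units; that floor lies within the scatter). The estimate for compound 4 is 30000 nM, with an expected range of 12000 nM to 50000 nM.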

Compound 4, half-maximal inhibitory concentration: 38100 nM
The estimate for compound 4 lay 1.3-fold (0.10 log units) below the measured number; the range from low to high includes it.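

In this assay, for the compounds shown here, the first measured change to the chain itself, a 1.1-fold higher number from compound 1 to compound 4 (0.04 log units; within the scatter), lies within the scatter, so 2-(butylcarbamoyl)ethyl and butylcarbamoyl at this place read alike. The floors an at least 1.3-fold lower number from compound 3 to compound 4 (0.11 log units; that floor lies within the scatter) and an at least 1.3-fold lower number from compound 2 to compound 4 (0.11 log units; that floor lies within the scatter) also lie within the scatter, so the butyl amide with the longer chain is not separated from the phenyl and 1-phenylethyl amides. Compound 2 and compound 3 each stand only at a limit: the limit of > 50000 nM in this assay, at which 2 of the 4 values shown sit.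

Going by these compounds, whether a longer chain, or a carboxylic acid in place of the butyl amide, gives a number beyond the scatter of compound 1 stays open.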